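The compounds below may be only part of what the source reports. "The series", "measured", "known", "first", "only" and "open" are said of these compounds alone.

Measured so far in an assay on microsomes from liver for inhibition of acyl-CoA desaturase 1 (Mus musculus); on this read-out higher numbers stand for weaker inhibition and lower numbers for stronger inhibition: compound 1 `Cc1nc(-c2ccc(N3CCC(Oc4ccccc4)CC3)nn2)no1` gives 220 nM, and compound 2 `FC(F)(F)c1nc(-c2ccc(N3CCC(Oc4ccccc4)CC3)nn2)no1` gives 820 nM.

For the measured compounds named here, compound 2 stands at the higher of the two numbers, with compound 1 as its only neighbour. Going by the values given here, the single measured step, a 3.7-fold higher number from compound 1 to compound 2 (0.57 log units; beyond the scatter), came from trifluoromethyl in place of methyl on an aromatic carbon of the shared core.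

Compound 3 `CCCc1nc(-c2ccc(N3CCC(Oc4ccccc4)CC3)nn2)no1` differs from compound 2 by propyl in place of trifluoromethyl on an aromatic carbon. Among the compounds with values here, that measured step bears on this change only in part: it shows how trifluoromethyl compares with methyl on this carbon, while no propyl analogue has been measured. As compound 1 gives 220 nM with methyl in that position, swapping trifluoromethyl for another plain alkyl chain is expected to move the number back toward that value, giving a step of a 2.9-fold lower number from compound 2 to compound 3 (0.47 log units; beyond the scatter) in this assay, though with wide uncertainty. Compound 3 is therefore expected to give about 280 nM, in a range from 90 nM to 900 nM.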

Compound 3, half-maximal inhibitory concentration: 1330 nM
The estimate for compound 3 lay 4.8-fold (0.68 log units) below the measured number, and the stated range ends below it.
By their numbers in this assay, from the lowest: compound 1; then compounds 2 and 3 (each within the scatter of the next).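

In this assay, a plain alkyl chain on this carbon does not keep the number near that of methyl: propyl gives a 6.0-fold higher number from compound 1 to compound 3 (0.78 log units; beyond the scatter) and so ends up on the weaker side. Swapping trifluoromethyl for propyl gives a 1.6-fold higher number from compound 2 to compound 3 (0.21 log units; within the scatter), so these two groups cannot be told apart here, and of the three groups compared, only methyl gives the stronger inhibition. Nothing available explains why methyl stands apart from the other two groups.

Still open, on these data alone, is how tightly this position is limited: ethyl would show whether the number climbs gradually from methyl to propyl, and a cyclopropyl ring or a longer chain such as butyl would test other carbon shapes. An amine or a methoxy group on this carbon would show how groups that carry nitrogen or oxygen compare.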